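The source may report more compounds than this note shows. Statements on the series, on what has been measured and on what is new or still open speak of the compounds shown alone.

Measured in an ADME assay on PBMC cells (Homo sapiens) for cytotoxicity; on this read-out lower numbers stand for higher toxicity in this test and higher numbers for lower toxicity in this test:
- Compound 1 `CCO/N=C(/c1ccc(Br)cc1)C1CCN(C(C)CCNC(=O)c2c(C)cc[n+]([O-])c2C)CC1`: > 177000 nM, a limit
- Compound 2 `CC(CCNC(=O)c1c(Cl)cncc1Cl)N1CCC(C(O)c2ccc(Br)cc2)CC1`: 198000 nM
- Compound 3 `CCO/N=C(/c1ccc(Br)cc1)C1CCN(C(CC)CCNC(=O)c2c(C)cc[n+]([O-])c2C)CC1`: > 177000 nM, a limit

Compound 3 has no exact number, only a limit of > 177000 nM, and it stands at the limit of > 177000 nM in this assay, at which 2 of the 3 values shown sit. Compound 4 `CCO/N=C(/c1ccc(Br)cc1)C1CCN(CCCNC(=O)c2c(C)cc[n+]([O-])c2C)CC1` has hydrogen in place of ethyl on a saturated chain carbon bound to an amine nitrogen in a ring and a saturated chain carbon. Among the compounds with values here, the one measured step that bears on this change is a step that the two limits leave unreadable from compound 1 to compound 3, and it gives no size or direction. Within the data shown here, compound 2 gives the only exact value, 198000 nM. No step beyond the scatter is therefore expected in this assay, and the estimated step is a number no higher from compound 3 to compound 4 (the limit leaves the size open). For compound 4 the estimate is 175000 nM, with an expected range from 80000 nM to 300000 nM.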

Compound 4, half-maximal cytotoxic concentration: 7500 nM
Compound 4: the middle estimate sits 23-fold (1.37 log units) above what was measured; measured number below the stated range.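

Only with hydrogen at this saturated chain carbon does the number fall in this assay: hydrogen in place of ethyl gives an at least 23-fold lower number from compound 3 to compound 4 (1.37 log units; beyond the scatter), and hydrogen in place of methyl gives an at least 23-fold lower number from compound 1 to compound 4 (1.37 log units; beyond the scatter). The earlier step between methyl and ethyl could not be read, whereas these two show that losing the group altogether matters here. Both sizes are minimums, because the starting compounds carry no exact number: the limit of > 177000 nM in this assay, at which 2 of the 4 values shown sit.

Whether methyl and ethyl differ stays unreadable. Also open, going by these compounds, are how a propyl group at this carbon would behave and whether the same change lowers the number on the core of compound 2.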